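A Protecting Group Comes Off the Chain End

The compounds below may be only part of what the source reports. "The series", "measured", "known", "first", "only" and "open" are said of these compounds alone.

Three compounds share one core and differ only at the end of the amide side chain. Compound 1 `CS(=O)(=O)NCCCNC(=O)CN1CN(c2ccccc2)C2(CCN(C(=O)c3ccc(C4CCCCC4)cc3)CC2)C1=O` gives 3800 nM in an assay on HEK293 cells for displacement of a labelled ligand from NPC1-like intracellular cholesterol transporter 1 (Homo sapiens); a higher number here means a weaker inhibitor, a lower number a stronger inhibitor. Compound 2 `CS(=O)(=O)N1CCN(C(=O)CN2CN(c3ccccc3)C3(CCN(C(=O)c4ccc(C5CCCCC5)cc4)CC3)C2=O)CC1` gives 6300 nM, and compound 3 `CC(C)(C)OC(=O)NCCNC(=O)CN1CN(c2ccccc2)C2(CCN(C(=O)c3ccc(C4CCCCC4)cc3)CC2)C1=O` gives 5500 nM. The steps among them are small: a 1.7-fold higher number from compound 1 to compound 2 (0.22 log units; within the scatter), a 1.4-fold higher number from compound 1 to compound 3 (0.16 log units; within the scatter) and a 1.1-fold lower number from compound 2 to compound 3 (0.06 log units; within the scatter). Compound 3 thus sits between the other two, and none of the three can be told apart from the others on these numbers.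

Compound 4 `NCCNC(=O)CN1CN(c2ccccc2)C2(CCN(C(=O)c3ccc(C4CCCCC4)cc3)CC2)C1=O` differs from compound 3 in one place: hydrogen in place of tert-butoxycarbonyl on an amine nitrogen. The tert-butoxycarbonyl leaves and a hydrogen enters on the amine nitrogen, so the chain now ends in an amino group. All three measured steps also changed this chain end, and every one stayed within the scatter. Among the compounds with values here, a step of similar size is therefore expected here, though no measured compound carries an amino group at this end, so the direction stays open. Compound 4 is expected to give 6000 nM, between 2000 nM and 20000 nM, which means an expected step of a 1.1-fold higher number from compound 3 to compound 4 (0.04 log units; within the scatter).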

Compound 4, half-maximal inhibitory concentration: 3800 nM
Beside the measured number, compound 4's estimate is 1.6-fold (0.20 log units) above it, within the range that was stated.
By their numbers in this assay, from the lowest: compounds 1, 4, 3 and 2 (each within the scatter of the next).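

Taking the tert-butoxycarbonyl off the amine nitrogen removes 7 heavy atoms, yet a 1.4-fold lower number from compound 3 to compound 4 (0.16 log units; within the scatter) is all that it does in this assay. The free amino group also fits the pattern of the earlier chain ends, as a 1.7-fold lower number from compound 2 to compound 4 (0.22 log units; within the scatter) and no change at the digits printed from compound 1 to compound 4 (within the scatter) both show, so all four chain ends shown remain indistinguishable on these numbers, and none goes against this. Nothing available here explains why this end of the side chain gives such similar numbers.

Still open, as far as these compounds go, is whether any group at this position can give a step beyond the scatter. A carboxylic acid at the chain end, or a longer chain carrying the same amino group, would test this.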